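Quinoline sulfonamides and a change at the amine

The source may hold more compounds than are shown below. What is called first, only, known or untested is meant among the compounds shown, and "the series" means these compounds.

Measured compounds:
- Compound 1 `O=S(=O)(c1cccc(Cl)c1)c1cnc2cc(Cl)ccc2c1N1CCC(CO)CC1`: 30.9 nM
- Compound 3 `CC1CCN(c2c(S(=O)(=O)c3ccc(Cl)cc3)cnc3ccc(Cl)cc23)CC1`: 435 nM
- Compound 2 `CCN1CCN(c2c(S(=O)(=O)c3ccccc3)cnc3ccccc23)CC1`: "not determined" (no result reported)

These compounds share a core carrying a sulfonyl-linked aromatic ring and a saturated amine ring. In an assay on isolated protein for displacement of a labelled ligand from metabotropic glutamate receptor 5 (Homo sapiens), with a stated time of 60 min (on this read-out lower numbers stand for stronger inhibition and higher numbers for weaker inhibition), compound 1 gives 30.9 nM, and in this assay compound 3 gives 435 nM, so the two measured compounds differ by more than the usual scatter, with compound 1 giving the lower number. In this assay compound 2 gives "not determined" (no result reported); nothing was reported for it, so it cannot be placed against the other two.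

Compound 4 `CC1CCN(c2c(S(=O)(=O)c3ccccc3)cnc3ccccc23)CC1` is the compound to be measured. Compared with compound 2 the change is 4-methylpiperidin-1-yl in place of 4-ethylpiperazin-1-yl on an aromatic carbon. Among the compounds with values here, since compound 2 has no result, the size and direction of this step in this assay cannot be foreseen from a starting value; no step between measured compounds covers this change either. Within the data shown here, the only guide is compound 3, which carries the same 4-methylpiperidin-1-yl group on a core that also bears two chlorines and gives 435 nM.

On that basis, compound 4 is expected to give about 700 nM in this assay, with a likely range from 150 nM to 3500 nM.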

Compound 4, inhibition constant: 108 nM
Compound 4: middle estimate off by 6.5-fold (0.81 log units), on the high side; the whole stated range lies above it.
By their numbers in this assay, from the lowest: compound 1; then compound 4; then compound 3.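

No new step can be read: compound 2 has no result to start from, and compound 3 differs from compound 4 in more than one place. As far as these compounds go, what swapping 4-ethylpiperazin-1-yl for 4-methylpiperidin-1-yl does on its own remains open, as does the separate effect of each chlorine. Nothing measured here explains the value of compound 4.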